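This account rests on a few compounds, and the source may have more. Where it says the series, first, only, none or still open, it means among the compounds named here.

Two compounds share one core and differ only in the group attached to a carbonyl carbon. In a functional assay on MCF7 cells (Homo sapiens) for inhibition, read by MTT assay, with a stated time of 72 h (on this read-out lower numbers stand for stronger inhibition and higher numbers for weaker inhibition), compound 1 `CN(C(=O)NC(=O)c1c(F)cccc1F)c1nc(C(F)(F)F)c(C(=O)N/N=C/c2cccc(C(F)(F)F)c2)s1` gives 21.8 ug/mL, while compound 2 `CN(C(=O)NC(=O)c1ccc(C(F)(F)F)cc1)c1nc(C(F)(F)F)c(C(=O)N/N=C/c2cccc(C(F)(F)F)c2)s1` gives 8.95 ug/mL, the lowest of the two numbers; the step of a 2.4-fold lower number from compound 1 to compound 2 (0.39 log units; beyond the scatter) lies beyond the scatter. Compound 3 `CN(C(=O)NC(=O)c1ccc([N+](=O)[O-])cc1)c1nc(C(F)(F)F)c(C(=O)N/N=C/c2cccc(C(F)(F)F)c2)s1` differs from compound 2 by nitro in place of trifluoromethyl on an aromatic carbon. No measured step bears on this exchange, since the only step shown concerns a different exchange on the carbonyl carbon, so the data give no direction for it. For compound 3 the expected step is a 1.0-fold higher number from compound 2 to compound 3 (0.00 log units; within the scatter), and its estimated value is 9 ug/mL, with a range from 4 ug/mL to 20 ug/mL.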

Compound 3, half-maximal inhibitory concentration: 4.39 ug/mL
Beside the measured number, compound 3's estimate is 2.1-fold (0.31 log units) above it, within the range that was stated.
By their numbers in this assay, from the lowest: compound 3; then compound 2; then compound 1.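

In this assay the change from trifluoromethyl to nitro on this aromatic carbon, para to a large group, gives a 2.0-fold lower number from compound 2 to compound 3 (0.31 log units; beyond the scatter) and shows that the group at this one place can still shift the number. Set against the 2,6-difluorophenyl group, the 4-nitrophenyl group gives a 5.0-fold lower number from compound 1 to compound 3 (0.70 log units; beyond the scatter) and this is the largest step among the three compounds. Nothing measured here says what lies behind these steps. On these data alone, what an amine or a carboxylic acid on this same carbon would do stays open.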